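Swapping Fluorine for Imidazole on the Aniline Ring

The source may report more compounds than this note shows. Statements on the series, on what has been measured and on what is new or still open speak of the compounds shown alone.

Of the compounds shown here, three sharing one core have been tested in a functional assay for inhibition, with Homo sapiens as the target; a higher number here means a weaker inhibitor, a lower number a stronger inhibitor. Compound 1 `Fc1ccc(Nc2nccc(-c3ccncc3)n2)cc1` gives 1900 nM, the second highest of the three numbers. Compound 2 `CN(C)c1cccc(Nc2nccc(-c3cccs3)n2)c1` gives 2400 nM, a number within the usual scatter of that of compound 1, so the two cannot be told apart. Compound 3 `COc1cccc(Nc2nccc(-c3cccnc3)n2)c1` gives 300 nM, a lower number than compound 1 by more than the scatter, the only clear gap among the three. Compound 4 `c1cc(-c2ccnc(Nc3ccc(-n4ccnc4)cc3)n2)ccn1` has not been measured. It differs from compound 1 in one place: 1H-imidazol-1-yl in place of fluoro on an aromatic carbon. Within the data shown here, no measured pair shows such a change, so the expectation rests on compound 1 alone. A modest step toward a lower number is expected, or none beyond the scatter, a 1.9-fold lower number from compound 1 to compound 4 (0.28 log units; within the scatter). Compound 4 is therefore estimated at 1000 nM in this assay, with a range from 300 nM to 4000 nM.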

Compound 4, half-maximal inhibitory concentration: 7600 nM
The estimate for compound 4 lay 7.6-fold (0.88 log units) below the measured number; the whole stated range lies below it.
By their numbers in this assay, from the lowest: compound 3; then compounds 1 and 2 (each within the scatter of the next); then compound 4.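

At the aromatic carbon para to a large group, 1H-imidazol-1-yl in place of fluoro gives a 4.0-fold higher number from compound 1 to compound 4 (0.60 log units; beyond the scatter) in this assay. This shows that the position responds to the group it carries, and that this five-membered aromatic ring, despite its hydrogen-bond acceptors, gives a weaker inhibitor than fluoro does here. Nothing available explains why the number rises. Going by these compounds, whether chloro or an amine at this place would give a lower number stays open. So does whether the same swap would have a similar effect on the other compounds in this series.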